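Cyano in place of fluoro: compound 3 to compound 4

The source may report more compounds than this note shows. Statements on the series, on what has been measured and on what is new or still open speak of the compounds shown alone.

Measured so far in an ADME assay on microsomes from liver (Homo sapiens) for metabolic stability, with a stated time of 10 min; on this read-out higher numbers stand for a more stable compound and lower numbers for a less stable compound
compound 1 `CC(=O)N1CC[C@@H](C(=O)N2CC[C@](c3ccc(C(OCc4c(F)cccc4F)(C(F)(F)F)C(F)(F)F)cc3)(S(=O)(=O)c3ccc(F)cc3)C2)C1` at 9%
compound 2 `O=C(N1CCOCC1)N1CC[C@](c2ccc(C(OCc3c(F)cccc3F)(C(F)(F)F)C(F)(F)F)cc2)(S(=O)(=O)c2ccc(F)cc2)C1` at 3%
compound 3 `CC(=O)N1CCN(C(=O)N2CC[C@](c3ccc(C(OCc4c(F)cccc4F)(C(F)(F)F)C(F)(F)F)cc3)(S(=O)(=O)c3ccc(F)cc3)C2)CC1` at 5%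

Steps of a number 4 percentage points lower from compound 1 to compound 3 (within the scatter) and a number 2 percentage points higher from compound 2 to compound 3 (within the scatter) leave compound 3 in the same low band as the other two. Compound 4 `CC(=O)N1CCN(C(=O)N2CC[C@](c3ccc(C(OCc4c(F)cccc4C#N)(C(F)(F)F)C(F)(F)F)cc3)(S(=O)(=O)c3ccc(F)cc3)C2)CC1` has one change, cyano in place of fluoro on an aromatic carbon turning 2,6-difluorobenzyl into 2-cyano-6-fluorobenzyl, on an aromatic carbon ortho to a large group. Among the compounds with values here, no measured step touches this place: all three alter the group on the carbonyl carbon, and a number 6 percentage points lower from compound 1 to compound 2 (within the scatter) is typical of them. The data therefore give no ground for expecting a move beyond the scatter in this assay here. The expected step is a number 1 percentage points higher from compound 3 to compound 4 (within the scatter) and no more than that. Compound 4 is estimated at 6% (expected range 2% to 15%).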

Compound 4, percent of the compound remaining: 0%
Estimate against measurement, compound 4: 6 percentage points above; the whole stated range lies above it.
By their numbers in this assay, from the lowest: compounds 4, 2, 3 and 1 (each within the scatter of the next).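

The earlier compounds shown here carry no change on this aromatic carbon of the 2,6-difluorobenzyl group; in this assay, cyano in place of fluoro gives a number 5 percentage points lower from compound 3 to compound 4 (within the scatter). With compound 3 at 5%, the read-out has little room left to fall, so this step cannot show how far the change might lower it. No measurement at hand bears on the result. Open, going by these compounds, is whether a methoxy or aminomethyl group on this carbon reads any differently, and whether cyano behaves alike with 1-acetylpyrrolidin-3-yl on the carbonyl carbon.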